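Hydroxy in place of fluoro: compound 2 to compound 4

The source may hold more compounds than are shown below. What is called first, only, known or untested is meant among the compounds shown, and "the series" means these compounds.

In a functional assay on HeLa cells (Homo sapiens) for cytotoxicity, read by MTT assay, with a stated time of 24 h (on this read-out higher numbers stand for weaker inhibition and lower numbers for stronger inhibition), compound 2 (`O=C1c2ccccc2OCC1Cc1ccc(F)cc1`) gives > 200000 nM, which is a limit of the assay and not a number. Compound 1 (`Cc1ccc2c(c1)OCC(Cc1ccc(O)cc1)C2=O`) gives 43000 nM and compound 3 (`COc1ccc(CC2COc3ccccc3C2=O)c(OC)c1`) gives 38300 nM, two values within the usual scatter of each other.

Compound 4 (`O=C1c2ccccc2OCC1Cc1ccc(O)cc1`) differs from compound 2 by hydroxy in place of fluoro on an aromatic carbon, para to a large group: hydroxy in place of fluoro on an aromatic carbon. For the measured compounds named here, no measured step isolates this change, so any expectation is indirect. Compound 1 also bears a hydroxy group, and its value of 43000 nM is the nearest guide. A moderate step toward stronger inhibition is therefore expected in this assay, although compound 4 may also remain at the limit. The estimated at least 2.8-fold lower number from compound 2 to compound 4 (0.45 log units; beyond the scatter) runs in that direction. For compound 4 the expected value is 70000 nM, with an estimated range of 30000 nM to 200000 nM.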

Compound 4, half-maximal inhibitory concentration: 42800 nM
Compound 4: the middle estimate sits 1.6-fold (0.21 log units) above what was measured, and the stated range covers the measured number.
By their numbers in this assay, from the lowest: compounds 3, 4 and 1 (each within the scatter of the next). At a limit, above all of these: compound 2.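

In this assay, for the compounds shown here, hydroxy in place of fluoro on an aromatic carbon, para to a large group, gives an at least 4.6-fold lower number from compound 2 to compound 4 (0.66 log units; beyond the scatter), the first readable step at this position. Compound 2 stands at a limit and not at a number, so the size of this step is only a minimum: the limit of > 200000 nM in this assay, at which 1 of the 4 values shown sits. With the hydroxy group in place, hydrogen in place of methyl on an aromatic carbon of the shared core gives a 1.0-fold lower number from compound 1 to compound 4 (0.00 log units; within the scatter), so that change has no readable effect on the number.

Still open, going by these compounds, is whether an amine or a carboxylic acid at this position would read like hydroxy or like fluoro. On these data alone, the true distance between the fluoro and hydroxy compounds also stays open, as does whether plain hydrogen at this position would match either one.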